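Cyanomethyl on the amide nitrogen of compound 1

The source may hold more compounds than are shown below. What is called first, only, known or untested is meant among the compounds shown, and "the series" means these compounds.

In a functional assay on MIA PaCa-2 cells (Homo sapiens) for antiproliferative activity (on this read-out higher numbers stand for an effect only at larger amounts of compound and lower numbers for an effect already at smaller amounts), compound 1 `Cc1cc2c(C(N)=O)cccc2n1-c1nc2c(c(NCc3ccccc3)n1)CCCC2` gives 128 nM and stands level, within the scatter, with compound 2 `Cc1cc2c(C(N)=O)cccc2n1-c1nc2c(c(NCc3ccccc3)n1)COCC2` at 146 nM in this series. Among the measured compounds shown here, compound 3 `C#CCNC(=O)c1cccc2c1cc(C)n2-c1nc2c(c(NCc3ccccc3)n1)CCCC2` gives 470 nM as the highest number so far. Compound 4 `Cc1cc2c(C(=O)NCC#N)cccc2n1-c1nc2c(c(NCc3ccccc3)n1)CCCC2` differs from compound 1 by cyanomethyl in place of hydrogen on an amide-type nitrogen in one place: cyanomethyl in place of hydrogen on an amide-type nitrogen. For the measured compounds named here, the only measured step at that nitrogen is a 3.7-fold higher number from compound 1 to compound 3 (0.56 log units; beyond the scatter) for propargyl in place of hydrogen, which is modest and beyond the scatter. A step of similar size and direction is expected, an estimated 3.1-fold higher number from compound 1 to compound 4 (0.49 log units; beyond the scatter) in this assay on this single precedent. Compound 4 is estimated at 400 nM with an expected range from 170 nM to 950 nM in this read-out.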

Compound 4, half-maximal effective concentration: 468 nM
Compound 4: the middle estimate sits 1.2-fold (0.07 log units) below what was measured; measured number inside the range.
By their numbers in this assay, from the lowest: compounds 1 and 2 (each within the scatter of the next); then compounds 4 and 3 (each within the scatter of the next).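

In this assay a second group on the amide nitrogen gives a step of the same size (a 3.7-fold higher number from compound 1 to compound 4 (0.56 log units; beyond the scatter)), so the rise seen with propargyl is not particular to that group. Cyano in place of ethynyl at the end of the chain leaves no readable difference (a 1.0-fold lower number from compound 3 to compound 4 (0.00 log units; within the scatter)). Nothing shown gives a reason for either step.

Open, on these data alone, is whether methyl or a longer chain ending in an amine stays closer to compound 1. Also open, as far as these compounds go, is whether cyanomethyl has the same effect on the core of compound 2.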